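The compounds below may be only part of what the source reports. "The series", "measured", "known", "first", "only" and "open" are said of these compounds alone.

Of the compounds shown here, three have been measured in a functional assay on cells for antagonist activity at C-X-C chemokine receptor type 4 (Homo sapiens), read by fluorescence and calcium flux, with stated times of 25 min and 90 s; a lower number here means a stronger inhibitor, a higher number a weaker inhibitor. Compound 1 `c1ccc(CN(CCCCN(C[C@H]2Cc3ccccc3CN2)[C@H]2CCCc3cccnc32)Cc2ccccn2)nc1` gives 664 nM in this assay. For compound 2 `c1ccc(CN(CCCCN(C[C@H]2Cc3ccccc3CN2)[C@H]2CCCc3cccnc32)Cc2ccccc2)cc1` this assay reports only a limit, > 16700 nM. Compound 3 `c1ccc2c(c1)CN[C@@H](CN(CCCCNCC1CCOCC1)[C@H]1CCCc3cccnc31)C2`, whose chain ends in an amine carrying an (oxan-4-yl)methyl group, gives 52.9 nM in this assay. Of the two compounds with a number, compound 3 holds the lower one, and its gap to compound 1 lies beyond the usual scatter, so compound 3 is the stronger inhibitor of the two. Compound 4 `O=S1(=O)CCC(NCCCCN(C[C@H]2Cc3ccccc3CN2)[C@H]2CCCc3cccnc32)CC1` differs from compound 3 in one place: 1,1-dioxothian-4-yl in place of (oxan-4-yl)methyl on an amine nitrogen. Both the leaving and the entering groups are six-membered non-aromatic rings with one hetero atom, so the shape of the chain end changes little. Going by the values given here, no measured pair in this set shows what such a swap does in this assay, so the expectation rests on compound 3 alone and on the modest size of the change. The step expected here is a 1.5-fold higher number from compound 3 to compound 4 (0.18 log units; within the scatter), small and without a firm direction. Compound 4 is therefore estimated at 80 nM in this assay, with a likely range from 25 nM to 300 nM.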

Compound 4, half-maximal inhibitory concentration: 45.5 nM
Beside the measured number, compound 4's estimate is 1.8-fold (0.25 log units) above it; the measured number falls inside the stated range.
By their numbers in this assay, from the lowest: compounds 4 and 3 (each within the scatter of the next); then compound 1. At a limit, above all of these: compound 2.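

Going by these compounds alone, putting 1,1-dioxothian-4-yl in place of (oxan-4-yl)methyl on an amine nitrogen gives a 1.2-fold lower number from compound 3 to compound 4 (0.07 log units; within the scatter) in this assay and is the first measured step between compounds that differ in only one place. This amine nitrogen therefore takes either six-membered non-aromatic ring with no difference that can be told from the scatter, although the entering group brings sulfur and double bonds outside aromatic rings. Nothing shown here explains why the two groups read alike.

The swap alters the ring and the way it is attached in one step, so a plain oxan-4-yl group on the same nitrogen would be needed to separate the two. On these data alone, whether a piperidine ring, a carboxylic acid or an open butyl chain would fit there as well also remains open.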